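The compounds below may be only part of what the source reports. "The series", "measured", "known", "first", "only" and "open" are said of these compounds alone.

Compound 1 `Cc1nn(-c2nc(-c3ccc(Cl)c(Cl)c3)c(SC(C)C)s2)c(C(=O)O)c1-c1cncnc1` stands at the weaker end of the two measured compounds: in a functional assay on BJAB cells (Homo sapiens) for antiproliferative activity, with a stated time of 4 days (a lower number here means that less compound is needed, a higher number that more compound is needed for the effect), compound 1 gives 22000 nM, while compound 2 `Cc1c(-c2cc(Cl)cc(Cl)c2)c(C(=O)O)nn1-c1nc(-c2cc(Cl)ccc2F)c(SC(C)C)s1` gives 4800 nM in this assay. Compound 3 `Cc1cc(C)cc(-c2c(C)nn(-c3nc(-c4ccc(Cl)c(Cl)c4)c(SC(C)C)s3)c2C(=O)O)c1` differs from compound 1 in one place only, (3,5-dimethylphenyl in place of pyrimidin-5-yl on an aromatic carbon), that is 3,5-dimethylphenyl in place of pyrimidin-5-yl on an aromatic carbon. Going by the values given here, no measured pair isolates this change, so its size is uncertain. For compound 3 a moderate step toward a lower number is expected, a 2.8-fold lower number from compound 1 to compound 3 (0.44 log units; beyond the scatter). Compound 3 is therefore estimated at 8000 nM, within a range from 2500 nM to 25000 nM.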

Compound 3, half-maximal effective concentration: 2700 nM
Compound 3: middle estimate off by 3.0-fold (0.47 log units), on the high side; the range from low to high includes it.
By their numbers in this assay, from the lowest: compounds 3 and 2 (each within the scatter of the next); then compound 1.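

On the aromatic carbon that bears the changing ring, with the rest of compound 1 held constant, 3,5-dimethylphenyl in place of pyrimidin-5-yl gives an 8.1-fold lower number from compound 1 to compound 3 (0.91 log units; beyond the scatter) in this assay. Going by these compounds alone, this is the first single-change comparison, and it shows that the number responds to the group at this position, beyond the scatter. Nothing available explains the step. The compounds shown leave open whether it follows the loss of the two ring nitrogens or the arrival of the two methyl groups. A plain phenyl or a pyridin-3-yl at this position would separate these two changes.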